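The source may hold more compounds than are shown below. What is called first, only, known or untested is meant among the compounds shown, and "the series" means these compounds.

Measured compounds in an assay on HEK293 cells for agonist activity at Toll-like receptor 8 (Homo sapiens), read by a luciferase reporter, with a stated time of 6 h; on this read-out lower numbers stand for an effect already at smaller amounts and higher numbers for an effect only at larger amounts of compound:
compound 1 `CCCCNc1nc(N)nc2c1CNCC2` gives 7.2 uM
compound 2 `CCCCNc1nc(N)nc2c1CCNC2` gives 0.6 uM
compound 3 `CCCCNc1nc(N)nc2c1CN(Cc1c[nH]c3ccccc13)CC2` gives 0.22 uM

Compound 1 stands at the highest number of the three in this assay; compound 2 and compound 3 both give lower numbers, and both gaps lie beyond the usual scatter. The step to compound 4 `CCCCNc1nc(N)nc2c1CN(C(=O)CC)CC2` changes compound 1 at one spot: propanoyl in place of hydrogen on an amine nitrogen in a ring. Going by the values given here, no pair of measured compounds shows this particular change, so its effect is unknown here. Compound 3 shows that a group placed on this ring nitrogen can go with a lower number, but that group is unrelated to propanoyl. For compound 4 the expected step in this assay is therefore a modest move to a lower number, about a 2.4-fold lower number from compound 1 to compound 4 (0.38 log units; beyond the scatter). Compound 4 is estimated at 3 uM, within 0.5 uM to 15 uM.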

Compound 4, minimum effective concentration: 0.4 uM
Beside the measured number, compound 4's estimate is 7.5-fold (0.88 log units) above it, and the stated range ends above it.
By their numbers in this assay, from the lowest: compounds 3, 4 and 2 (each within the scatter of the next, the first and the last beyond it); then compound 1.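

In this assay, propanoyl in place of hydrogen on this amine nitrogen in a ring gives a large step, an 18-fold lower number from compound 1 to compound 4 (1.26 log units; beyond the scatter). So far only compound 3 had shown a group on this nitrogen going with a lower number, and propanoyl now shows that a group with no ring can do so too. Nothing measured here explains the size of this step. The compounds shown do not tell how a plain propyl chain, without the carbonyl, or a longer hexanoyl chain would behave on this nitrogen.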